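The compounds below may be only part of what the source reports. "The series", "measured", "known", "first", "only" and "open" are said of these compounds alone.

Compound 1 `COc1ccc(C(=O)NC2CCN(Cc3ccc4ccccc4c3)CC2)cc1OC` gives 1000 nM in an assay on isolated protein for binding affinity to melanin-concentrating hormone receptor 1 (Homo sapiens) (on this read-out higher numbers stand for weaker inhibition and lower numbers for stronger inhibition), the higher of the two numbers recorded, while compound 2 `COc1cc(C(=O)NC2CCN(Cc3ccc4ccccc4c3)CC2)cc(OC)c1OC` gives 286 nM in this assay, a step of a 3.5-fold lower number from compound 1 to compound 2 (0.54 log units; beyond the scatter). Compound 3 `COc1cc(C(=O)NC2CCN(Cc3ccc4ccccc4c3)CC2)ccc1F` differs from compound 1 by fluoro in place of methoxy on an aromatic carbon. Going by the values given here, the single measured step concerns a methoxy added at a different aromatic carbon and does not bear directly on this exchange, so only a modest change is expected, in either direction. Compound 3 is therefore estimated at 1500 nM (range 500 nM to 4500 nM), a step of a 1.5-fold higher number from compound 1 to compound 3 (0.18 log units; within the scatter).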

Compound 3, inhibition constant: 13 nM
Compound 3: the middle estimate sits 120-fold (2.06 log units) above what was measured, and the stated range ends above it.
By their numbers in this assay, from the lowest: compound 3; then compound 2; then compound 1.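

In this assay, fluoro in place of methoxy, para to a large group, gives a 77-fold lower number from compound 1 to compound 3 (1.89 log units; beyond the scatter), a large step. This aromatic carbon therefore responds strongly to the group it carries, and a methoxy there is not needed for a low number. Nothing measured here accounts for the size of this step. From the compounds shown here alone, it remains open whether the drop belongs to fluoro itself or simply to the loss of methoxy, which hydrogen, chloro or a nitrile at this carbon would help separate. Also open, going by these compounds, is what the remaining methoxy, ortho to this position, contributes.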